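The source may report more compounds than this note shows. Statements on the series, on what has been measured and on what is new or still open speak of the compounds shown alone.

Of the compounds shown here, two from this series have been tested in an assay on isolated protein for inhibition of serine/threonine-protein kinase Chk2 (Homo sapiens), read by mobility shift assay, tested at 30 uM; on this read-out lower numbers stand for less inhibition and higher numbers for more inhibition at the one concentration tested (going by the name of the read-out). Compound 1, `Nc1n[nH]c2cc(CC3CCNCC3)[nH]c(=O)c12`, gives 7% in this assay. Compound 2, `COCCNc1nc(C)cc2nn(-c3ccccc3)c(N)c12`, gives 4% in this assay. Compound 2 stands with compound 1 at the low end of the scale: the two numbers are indistinguishable within the usual scatter of this read-out, and the inhibition in this assay is level for the pair. Within the data shown here, no pair of measured compounds differing in one place is available, so no measured step guides the next comparison.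

Compound 3, `Cc1cc2nn(-c3ccccc3)c(N)c2c(N2CCCCC2)n1`, has not yet been measured. It differs from compound 2 in one place: piperidin-1-yl in place of (2-methoxyethyl)amino on an aromatic carbon. Since compound 2 shows only marginal inhibition and compound 1, with a different substitution pattern, shows the same, the step of a number 2 percentage points higher from compound 2 to compound 3 (within the scatter) is expected to be small, with no direction beyond the scatter that can be predicted from the two numbers at hand. For compound 3 in this assay an inhibition of about 6% is estimated, within a range from 0% to 20%.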

Compound 3, a percentage reported as inhibition, at one concentration (the size of the read-out at that concentration, not a potency): 4%
Beside the measured number, compound 3's estimate is 2 percentage points above it; the range from low to high includes it.
By their numbers in this assay, from the lowest: compounds 2, 3 and 1 (each within the scatter of the next).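

In this assay, among these compounds, the first one-place comparison, piperidin-1-yl in place of (2-methoxyethyl)amino on an aromatic carbon next to the ring nitrogen gives no change at the digits printed from compound 2 to compound 3 (within the scatter). At this position, then, an open chain carrying a hydrogen-bond donor and a six-membered non-aromatic ring without one are not told apart by this read-out, and both compounds stay at the low end of the scale, level with compound 1. No independent measurement is available to explain why the exchange leaves the number level.

The compounds shown leave open whether any group at this position can move the number beyond the scatter, for example a carboxylic acid, a primary amine or a longer chain ending in an amine. They also leave open whether a change elsewhere on the shared core, such as an ethyl group or a hydrogen in place of the methyl group, would give more inhibition than the level seen so far.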